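From tert-butyl to benzyl on the amide nitrogen

This account rests on a few compounds, and the source may have more. Where it says the series, first, only, none or still open, it means among the compounds named here.

Compound 1 `CC(C)(C)NC(=O)CCc1cccc2c1B(O)OC2`: > 100000 nM
Compound 2 `O=C(CCc1cccc2c1B(O)OC2)Nc1ccccc1`: 230 nM

In a functional assay on MDA-MB-231 cells (Homo sapiens) for antiproliferative activity, read by MTT assay, with a stated time of 72 h (on this read-out higher numbers stand for weaker inhibition and lower numbers for stronger inhibition), compound 1 gives > 100000 nM. This value is a limit of the assay and not a number. Compound 1 therefore stands at the limit of > 100000 nM in this assay, at which 1 of the 2 values shown sits.

Compound 2 differs from compound 1 by having phenyl in place of tert-butyl on an amide-type nitrogen. This change gives an at least 430-fold lower number from compound 1 to compound 2 (2.63 log units; beyond the scatter), which lies well beyond the usual scatter. Among the measured compounds shown here, it is the only measured step that bears on the next compound.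

Compound 3 `O=C(CCc1cccc2c1B(O)OC2)NCc1ccccc1` keeps the shared core but changes the same group: benzyl in place of tert-butyl on an amide-type nitrogen. Like phenyl, benzyl brings one six-membered aromatic ring of carbon only, which tert-butyl lacks. For the measured compounds named here, from the single step seen with compound 2, a large step towards lower numbers is expected in this assay. Benzyl is not phenyl, however, so the full size of that step need not carry over, and the expected range is wide.

Expressed as a step, the estimate is an at least 120-fold lower number from compound 1 to compound 3 (2.09 log units; beyond the scatter).

For compound 3 the estimated value is 800 nM, with an expected range of 150 nM to 8000 nM.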

Compound 3, half-maximal inhibitory concentration: > 100000 nM
Compound 3: no number, only a limit (the forecaster's own chance of this, stated with the estimate: 10%); middle value at least 120-fold (2.09 log units) away from the limit.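

Carrying a six-membered aromatic ring of carbon only on the amide nitrogen is not enough by itself for activity in this assay: compound 3 has such a ring within its benzyl group and gives > 100000 nM, which is a limit of the assay and not a number. Benzyl in place of phenyl on the same nitrogen gives an at least 430-fold higher number from compound 2 to compound 3 (2.63 log units; beyond the scatter), so this position separates two closely related aromatic groups very sharply. The step from compound 1 to compound 3 cannot be read, and of the three compounds only compound 2 gives a number rather than a limit: the limit of > 100000 nM in this assay, at which 2 of the 3 values shown sit.

The compounds shown leave open whether the activity of compound 2 depends on an unchanged phenyl ring or would survive a fluorine or a methoxy group placed on it. They also leave open how this assay would respond to a longer chain, such as 2-phenylethyl, on the amide nitrogen, or to an amine or a carboxylic acid added to the aromatic ring.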